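Swapping fluoro for bromo on the aryl ring

The compounds below may be only part of what the source reports. "The series", "measured", "known", "first", "only" and "open" are said of these compounds alone.

Compound 1 `COc1ccc(/C=C2\CC[C@H]3C(C)(C)CCC[C@]3(C)[C@H]2CCC(C)CC(=O)O)cc1`: in a functional assay on THP-1 cells (Homo sapiens) for cytotoxicity, read by MTT assay, with a stated time of 72 h (on this read-out lower numbers stand for stronger inhibition and higher numbers for weaker inhibition), compound 1 reaches only the limit > 200000 nM.
Compound 2 `CC(CC[C@H]1/C(=C/c2ccc([N+](=O)[O-])cc2)CC[C@H]2C(C)(C)CCC[C@]12C)CC(=O)O`: in this assay compound 2 gives 68000 nM.
Compound 3 `CC(CC[C@H]1/C(=C/c2ccc(F)cc2)CC[C@H]2C(C)(C)CCC[C@]12C)CC(=O)O`: in this assay compound 3 reaches only the limit > 200000 nM.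

Compound 3 stands at a limit of the assay, not at a number. The same is true of compound 1, so two of the three values sit at the limit of > 200000 nM in this assay, at which 2 of the 3 values shown sit. Compound 2 is the only one of the three with a measured number.

The change to compound 4 `CC(CC[C@H]1/C(=C/c2ccc(Br)cc2)CC[C@H]2C(C)(C)CCC[C@]12C)CC(=O)O` is bromo in place of fluoro on an aromatic carbon. Within the data shown here, none of the measured steps involves bromo. The steps known so far concern the same ring position: an at least 2.9-fold lower number from compound 1 to compound 2 (0.46 log units; beyond the scatter), and an at least 2.9-fold higher number from compound 2 to compound 3 (0.46 log units; beyond the scatter), whereas a step that the two limits leave unreadable from compound 1 to compound 3. They show that a change at this position can move the number beyond the scatter, but they say nothing about bromo itself.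

For compound 4 the expectation is therefore no step beyond the scatter, namely an at least 1.3-fold lower number from compound 3 to compound 4 (0.12 log units; that floor lies within the scatter), with a real chance that the measurement again returns only a limit. The estimate for compound 4 is 150000 nM, within 50000 nM to 300000 nM.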

Compound 4, half-maximal inhibitory concentration: > 200000 nM
Compound 4 gave a limit, no number (the forecaster's own chance of this, stated with the estimate: 55%); middle value at least 1.3-fold (0.12 log units) away from the limit.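

With bromo on the ring, compound 4 also ends at a limit in this assay, not at a number, so bromo joins fluoro and methoxy as a third group at this position that gives no measured value: the limit of > 200000 nM in this assay, at which 3 of the 4 values shown sit.

Only the comparison with the nitro group can be read, and it shows an at least 2.9-fold higher number from compound 2 to compound 4 (0.46 log units; beyond the scatter), so compound 2 still stands apart from all three other compounds, now including the one with the heavier halogen. The steps from compound 1 and from compound 3 to compound 4 cannot be read, as both ends of each are limits, so nothing can be said about how bromo ranks against fluoro or methoxy.

As far as these compounds go, how far the true values of compounds 1, 3 and 4 lie from the limit, and whether they differ from one another at all, stays open. From the compounds shown here alone, it is also open whether the nitro result in compound 2 is a lone case or whether another group on this ring, such as an amine or a nitrile, would also give a measured number.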